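Cyclic amine replaces an amino alcohol on the alkyne

A few compounds are considered here, and "the series" means these few. Any claim that something is new, unique, unknown or untested is made for them only; others in the source may bear on it.

Compound 1 `COc1cc[nH]c1/C=C1\C(=O)Nc2ccc(F)c(C#C[C@@H](C)O)c21`: 130 nM
Compound 2 `COc1cc[nH]c1/C=C1\C(=O)Nc2ccc(F)c(C#CC(O)CN)c21`: 110 nM
Compound 3 `CCN[C@H](C#Cc1c(F)ccc2c1/C(=C/c1[nH]ccc1OC)C(=O)N2)[C@@H](C)O`: 549 nM

In a functional assay on SW480 cells (Homo sapiens) for inhibition (on this read-out higher numbers stand for weaker inhibition and lower numbers for stronger inhibition), compound 2 shows the lowest number of the three, though the step of a 1.2-fold lower number from compound 1 to compound 2 (0.07 log units; within the scatter) lies within the scatter, so compounds 1 and 2 cannot be told apart. The step of a 5.0-fold higher number from compound 2 to compound 3 (0.70 log units; beyond the scatter) is clearly beyond it. Compound 4 `COc1cc[nH]c1/C=C1\C(=O)Nc2ccc(F)c(C#C[C@@H]3CCCN3)c21` differs from compound 2 by pyrrolidin-2-yl in place of 2-amino-1-hydroxyethyl on a triple-bonded carbon. Among the compounds with values here, two measured steps bear on this: a 1.2-fold lower number from compound 1 to compound 2 (0.07 log units; within the scatter) shows that adding an amine changed little, while a 5.0-fold higher number from compound 2 to compound 3 (0.70 log units; beyond the scatter) shows that a more substituted amine raised the number. Compound 4 also carries a substituted amine and loses the hydroxyl, so a modest rise is expected, a 2.3-fold higher number from compound 2 to compound 4 (0.36 log units; beyond the scatter). Compound 4 is therefore estimated at 250 nM, with a range from 90 nM to 700 nM.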

Compound 4, half-maximal inhibitory concentration: 40 nM
Compound 4: the middle estimate sits 6.3-fold (0.80 log units) above what was measured, outside the stated range (below it).
By their numbers in this assay, from the lowest: compound 4; then compounds 2 and 1 (each within the scatter of the next); then compound 3.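

On the triple-bonded carbon, a ring amine with no hydroxyl is tolerated in this assay: a 2.8-fold lower number from compound 2 to compound 4 (0.44 log units; beyond the scatter) and a 3.3-fold lower number from compound 1 to compound 4 (0.51 log units; beyond the scatter) show that neither the hydroxyl nor an open chain is needed for a low number. With a 14-fold lower number from compound 3 to compound 4 (1.14 log units; beyond the scatter) as well, a substituted amine does not by itself raise the number, as compound 3 alone had suggested. No measurement here explains these differences. The compounds shown leave open whether a piperidin-2-yl or azetidin-2-yl ring, or pyrrolidin-2-yl with the opposite stereocentre, would do as well.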